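The source may report more compounds than this note shows. Statements on the series, on what has been measured and on what is new or still open speak of the compounds shown alone.

Three compounds have been measured in a functional assay on MCF7 cells (Homo sapiens) for cytotoxicity, read by MTT assay, with a stated time of 24 h, tested at 0.64 ug/mL; a lower number here means a weaker effect, a higher number a stronger effect of the compound at the concentration tested:

Compound 1 `Cc1nnc(SCC(=O)Nc2ccc(-c3nc(-c4ccccc4)c(-c4ccccc4)n3C)cc2)s1`: 35.1%
Compound 2 `Cn1c(-c2ccc(NC(=O)CSC3=NCCS3)cc2)nc(-c2ccccc2)c1-c1ccccc1`: 10.3%
Compound 3 `Cn1c(-c2ccc(NC(=O)CN3CCN(c4ccccc4)CC3)cc2)nc(-c2ccccc2)c1-c1ccccc1`: 12.1%

Compound 3 stands second highest of these three numbers. Its nearest neighbour is compound 2, with a change of a number 1.8 percentage points higher from compound 2 to compound 3 (within the scatter), which lies within the scatter of repeated measurements. The furthest is compound 1, and the change of a number 23 percentage points lower from compound 1 to compound 3 (beyond the scatter) is beyond the scatter, so compound 1 is the only one of the three that clearly stands apart.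

Compound 4 `Cn1c(-c2ccc(NC(=O)CN3CCN(Cc4ccc(Cl)cc4)CC3)cc2)nc(-c2ccccc2)c1-c1ccccc1` is the compound not yet measured. It differs from compound 3 in one place: 4-chlorobenzyl in place of phenyl on an amine nitrogen in a ring. Among the compounds with values here, no measured step alters a group at that spot. The steps that come closest are those that exchanged the whole group on the saturated chain carbon bound to the carbonyl carbon: compound 1 to compound 2 gave a number 24.8 percentage points lower from compound 1 to compound 2 (beyond the scatter), and compound 2 to compound 3 gave a number 1.8 percentage points higher from compound 2 to compound 3 (within the scatter), the latter within the scatter. Since the ring that carries the changed group is kept and only the group on its amine nitrogen is exchanged, the expected step in this assay is small, a number 1.9 percentage points higher from compound 3 to compound 4 (within the scatter), in no clear direction beyond the scatter. Compound 4 is therefore estimated at 14%, with a range from 4% to 28%.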

Compound 4, a percentage reported as activity, at one concentration (the size of the read-out at that concentration, not a potency): 4.8%
The estimate for compound 4 lay 9.2 percentage points above the measured number; low and high end bracket the measured number.
By their numbers in this assay, from the lowest: compounds 4, 2 and 3 (each within the scatter of the next); then compound 1.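

Within the data shown here, the exchange of phenyl for 4-chlorobenzyl is the first measured change on the amine nitrogen in the ring, and it gives a number 7.3 percentage points lower from compound 3 to compound 4 (within the scatter) in this assay. This step cannot be told apart from the scatter of repeated measurements, so at this one concentration the exchange shows no clear effect in either direction, even though the entering group is larger than the phenyl it replaces. The exchange also brings in a chlorine and an additional carbon together, so these two parts cannot be judged separately, and nothing measured here offers an explanation for the result.

The compounds shown leave open whether plain benzyl, without the chlorine, or a simple methyl on this nitrogen would give a step beyond the scatter, and whether moving to a 4-methoxybenzyl or a 4-fluorobenzyl group would behave like 4-chlorobenzyl. As far as these compounds go, a read-out at a single concentration is also not a potency, so how compound 3 and compound 4 would compare across a range of concentrations remains open.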